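Moving from a urea-type linkage to a simple amide

This account rests on a few compounds, and the source may have more. Where it says the series, first, only, none or still open, it means among the compounds named here.

Measured so far:
compound 1 `CCCCCc1cccc(NC(=O)NCCCCl)c1`: 26000 nM
compound 2 `CCCCCc1cccc(NC(=O)NC(=O)CCl)c1`: 8300 nM

In a functional assay on MCF7 cells (Homo sapiens) for antiproliferative activity, with a stated time of 48 h (a lower number here means a stronger inhibitor, a higher number a weaker inhibitor), compound 2 gives the lower of the two numbers. Going by the values given here, the only measured change is a 3.1-fold lower number from compound 1 to compound 2 (0.50 log units; beyond the scatter), which exchanged a chain for a carbonyl-bearing group on the nitrogen. Compound 3 `CCCCCc1cccc(NC(=O)CCCCl)c1` differs from compound 2 in that (3-chloropropyl in place of ((chloromethyl)carbonyl)amino on a carbonyl carbon). Here a whole carbonyl-bearing amino group leaves and a chain enters on the carbonyl carbon, so no measured step matches this change directly; the earlier step only hints that such groups matter. Compound 3 is therefore expected to show a modest rise, a 1.8-fold higher number from compound 2 to compound 3 (0.26 log units; within the scatter). Compound 3 is estimated at 15000 nM, between 5000 nM and 50000 nM.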

Compound 3, half-maximal inhibitory concentration: > 100000 nM
Compound 3: no number, only a limit; the forecaster's own chance of this, stated with the estimate: 10%; at least 6.6-fold (0.82 log units) between middle value and limit.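

In this assay compound 3 gives > 100000 nM, which is a limit of the assay and not a number: the limit of > 100000 nM in this assay, at which 1 of the 3 values shown sits. Replacing the amino part on the carbonyl carbon with 3-chloropropyl weakens activity in both comparisons, with an at least 12-fold higher number from compound 2 to compound 3 (1.08 log units; beyond the scatter) and an at least 3.8-fold higher number from compound 1 to compound 3 (0.58 log units; beyond the scatter). The two compounds with a measured number both keep a nitrogen on this carbonyl carbon, whichever group that nitrogen carries, while compound 3 has none there.

Going by these compounds, whether a plain amino group on that carbonyl carbon would be enough to keep activity remains open. On these data alone, the part played by the chlorine, present in all three compounds, also remains open.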